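This account rests on a few compounds, and the source may have more. Where it says the series, first, only, none or still open, it means among the compounds named here.

In a functional assay on HOS cells (Homo sapiens) for antiproliferative activity, with a stated time of 72 h (on this read-out higher numbers stand for weaker inhibition and lower numbers for stronger inhibition), compound 1 `OC[C@H]1O[C@@H](n2cnc3c(NCc4ccc(Cl)cc4)ncnc32)[C@H](O)[C@@H]1O` gives > 166000 nM as a limit of the assay, not a number. Compound 2 `Cc1ccc(CNc2ncnc3c2ncn3[C@@H]2O[C@H](CO)[C@@H](O)[C@H]2O)cc1` gives > 166000 nM as a limit too, so it offers no exact potency to start from. The evidence so far is the limit of > 166000 nM in this assay, at which 2 of the 2 values shown sit, and nothing finer. Among the measured compounds shown here, the only measured step is a step that the two limits leave unreadable from compound 1 to compound 2 and supplies no size to carry forward. Compound 3 `OC[C@H]1O[C@@H](n2cnc3c(NCc4ccc(Cl)c(Cl)c4)ncnc32)[C@H](O)[C@@H]1O` keeps the shared core and carries 3,4-dichlorophenyl in place of 4-methylphenyl on a saturated chain carbon bound to a nitrogen on an aromatic ring, a change from compound 2 counted as 3,4-dichlorophenyl in place of 4-methylphenyl on a saturated chain carbon bound to a nitrogen on an aromatic ring and the only difference between the two. Clear activity in this assay is not expected because of the limit of > 166000 nM in this assay, at which 2 of the 2 values shown sit, and the likeliest result is another limit. The expected change is a number no higher from compound 2 to compound 3 (the limit leaves the size open) and the estimate points to no step beyond the scatter in either direction. For compound 3 the estimate is 166000 nM with an expected range from 60000 nM to 300000 nM and a good chance of only a limit.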

Compound 3, half-maximal inhibitory concentration: > 166000 nM
Compound 3: no number, only a limit; the forecaster's own chance of this, stated with the estimate: 75%; the middle value lies on the limit itself.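

In this assay compound 3 gives > 166000 nM, which is a limit and not a number. No new step can be read between compound 1, compound 2 and compound 3. The compounds shown leave open how these three rank against one another in this assay, and whether any other group at this place would give a number rather than a limit.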